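A few compounds are considered here, and "the series" means these few. Any claim that something is new, unique, unknown or untested is made for them only; others in the source may bear on it.

Working notes on the series

The four compounds share one core, an amide-linked benzyl unit bearing a methoxy group, joined through a spacer to a second aromatic ring. Compound 1 `COc1cc(CNC(=O)CCCCCCC(C)C)ccc1OC(=O)CCC(=O)Oc1ccc(C(N)=S)cc1` has an ester-type spacer and a thioamide on the far ring; in a functional assay on MCF7 cells (Homo sapiens) for antiproliferative activity, read by MTT assay, with a stated time of 48 h (on this read-out lower numbers stand for stronger inhibition and higher numbers for weaker inhibition), compound 1 has "not determined" (no result reported), no number being reported. Compound 2 `COc1cc(CNC(=O)CCCCCCC(C)C)ccc1OCCCCCOc1ccc(-c2cc(=S)ss2)cc1` carries the saturated chain on the amide and the dithiolethione ring on the far aromatic ring; in this assay compound 2 gives 48700 nM. Compound 3 `COc1cc(CNC(=O)CCCC/C=C/C(C)C)ccc1OCCCCCOc1ccc(C(N)=S)cc1` carries the unsaturated chain and the thioamide; in this assay compound 3 gives 17200 nM, the lowest of the two numbers available, and compound 2 stands clearly beyond the scatter from it.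

Compound 4 `COc1cc(CNC(=O)CCCC/C=C/C(C)C)ccc1OCCCCCOc1ccc(-c2cc(=S)ss2)cc1` differs from compound 3 in one place: a group of 6 heavy atoms (3 carbon, 3 sulfur; one five-membered aromatic ring with 2 hetero atoms) in place of a group of 3 heavy atoms (1 carbon, 1 nitrogen, 1 sulfur; no ring), on an aromatic carbon. Within the data shown here, no single-change step between measured compounds is known; compound 2 and compound 3 differ in two places at once, so their gap can only hint at the effect of the entering ring. On that hint, the step in this assay is expected to go toward a higher number, of moderate size, since compound 2 with the same entering group gives 48700 nM against compound 3 at 17200 nM. For compound 4 the estimate is 35000 nM, with a range of 12000 nM to 100000 nM, an expected step of a 2.0-fold higher number from compound 3 to compound 4 (0.31 log units; beyond the scatter).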

Compound 4, half-maximal inhibitory concentration: > 50000 nM
Compound 4 gave a limit, no number; the forecaster's own chance of this, stated with the estimate: 10%; middle value at least 1.4-fold (0.15 log units) from the limit.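

With the unsaturated chain held fixed, putting the dithiolethione ring in place of the thioamide on an aromatic carbon, para to a large group, now gives a direct reading: an at least 2.9-fold higher number from compound 3 to compound 4 (0.46 log units; beyond the scatter), so even the floor of this step lies beyond the scatter and the change weakens antiproliferative activity. In this assay compound 4 gives > 50000 nM, which is a limit and not a number: the limit of > 50000 nM in this assay, at which 1 of the 4 values shown sits. With the ring held fixed, 3-methylbut-1-en-1-yl in place of isopentyl gives an at least 1.0-fold higher number from compound 2 to compound 4 (0.01 log units; that floor lies within the scatter), and because that floor lies within the scatter, this pair does not show what the chain change does.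

Going by these compounds, it remains open whether the weaker result comes from the entering dithiolethione ring itself or from the loss of the thioamide, and whether a smaller far-ring group such as a nitrile or a carboxylic acid would stay close to compound 3 at 17200 nM. On these data alone, how a longer chain on the amide would act on either far-ring group also remains open.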